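Swapping a methoxy for a chloro on a weakly active urea

A few compounds are considered here, and "the series" means these few. Any claim that something is new, unique, unknown or untested is made for them only; others in the source may bear on it.

Of the compounds shown here, three built on a shared core have been measured in a functional assay on PC-3 cells (Homo sapiens) for inhibition, with a stated time of 72 h; on this read-out higher numbers stand for weaker inhibition and lower numbers for stronger inhibition. Compound 1 `COc1ccc(NC(=O)Nc2nc(Sc3c[nH]c4ccccc34)cc(N3CCCCC3)n2)cc1` gives 17400 nM. Compound 2 `O=C(Nc1ccccc1)Nc1nc(NC2CC2)cc(Sc2c[nH]c3ccccc23)n1` gives 17500 nM, and compound 3 `COc1ccc(NC(=O)Nc2nc(Nc3cc(OC)cc(OC)c3)cc(Sc3c[nH]c4ccccc34)n2)cc1` gives 15100 nM. Within the data shown here, the three numbers lie within the scatter of one another, so compound 1 is not separated from either of its companions; the one single-point step that is known, a 1.2-fold lower number from compound 1 to compound 3 (0.06 log units; within the scatter), sits at a different part of the molecule from the change examined here.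

The new compound 4 `O=C(Nc1ccc(Cl)cc1)Nc1nc(Sc2c[nH]c3ccccc23)cc(N2CCCCC2)n1` differs from compound 1 in one place: chloro in place of methoxy on an aromatic carbon. Among the measured compounds shown here, no measured pair isolates this change. For the measured compounds named here, compound 2 also carries an unsubstituted phenyl instead of the methoxyphenyl, yet it differs from compound 1 at a second site as well, so its number shows only that this combination of changes left the read-out within the scatter. With every known step small and nothing pointing to a particular direction, the expectation for this assay is a step of a 1.0-fold lower number from compound 1 to compound 4 (0.01 log units; within the scatter), that is, no move beyond the scatter. Compound 4 is therefore estimated at 17000 nM, expected to fall between 8000 nM and 36000 nM.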

Compound 4, half-maximal inhibitory concentration: 42500 nM
Beside the measured number, compound 4's estimate is 2.5-fold (0.40 log units) below it; measured number outside the range, above it.
By their numbers in this assay, from the lowest: compounds 3, 1 and 2 (each within the scatter of the next); then compound 4.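

In this assay chloro in place of methoxy gives a 2.4-fold higher number from compound 1 to compound 4 (0.39 log units; beyond the scatter) and this is the first single-place step shown here to leave the scatter, though only modestly. Among these compounds, the only earlier step of this kind, a 1.2-fold lower number from compound 1 to compound 3 (0.06 log units; within the scatter), changed a different part of the molecule and did not separate its two compounds, so this result is the first sign that the read-out responds to a change in one place: the group on the 4-methoxyphenyl, where chloro moves the number towards weaker inhibition. Nothing available explains why the swap has this effect.

The compounds shown leave open how other groups at this place, such as fluoro, methyl, dimethylamino or a carboxylic acid, would compare with methoxy and chloro, and whether any of them would give a lower number than compound 1. Going by these compounds, it also remains open whether chloro in place of methoxy would have a similar effect on compound 3, which carries (3,5-dimethoxyphenyl)amino where compound 1 carries piperidin-1-yl.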